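The source may report more compounds than this note shows. Statements on the series, on what has been measured and on what is new or still open speak of the compounds shown alone.

Of the compounds shown here, three sharing one core have been measured in a physicochemical assay for permeability, using PAMPA; a higher number here means that the compound crosses the layer faster, a lower number that the compound crosses the layer more slowly. Compound 1 `CC[C@@H]1C[C@H](CC)CN(CCCNC(=O)C2CCN(Cc3nc(-c4ccccc4C)oc3C)CC2)C1` gives 1270 10^-6 cm/s. Compound 2 `Cc1ccccc1-c1nc(CN2CCC(C(=O)NCCCN3CC(C)(C)CC(C)(C)C3)CC2)c(C)o1` returns only a limit of the assay, > 1390 10^-6 cm/s. Compound 3 `Cc1ccccc1-c1nc(CN2CCC(C(=O)NCCCN3CC4CCCC(C4)C3)CC2)c(C)o1` gives 331 10^-6 cm/s and stands lowest of the three.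

Compound 4 `CCCN(CCC)CCNC(=O)C1CCN(Cc2nc(-c3ccccc3C)oc2C)CC1` has not yet been measured in this assay. Going to it from compound 3, the structural change is a group of 7 heavy atoms (6 carbon, 1 nitrogen; no ring) in place of a group of 10 heavy atoms (9 carbon, 1 nitrogen; one six-membered non-aromatic ring of carbon only, one six-membered non-aromatic ring with 1 hetero atom), on a saturated chain carbon, two bonds along the chain from an amide-type nitrogen. The incoming dipropylamino group has no ring, so the six-membered non-aromatic ring of carbon only is lost.

The three measured steps each exchange one group for another on a saturated chain carbon, three bonds along the chain from an amide-type nitrogen. The step of an at least 1.0-fold higher number from compound 1 to compound 2 (0.03 log units; that floor lies within the scatter) stays within the scatter, while the steps of a 3.8-fold lower number from compound 1 to compound 3 (0.58 log units; beyond the scatter) and an at least 4.1-fold lower number from compound 2 to compound 3 (0.62 log units; beyond the scatter) are modest and beyond it. Within the data shown here, both of those larger steps end at compound 3, the only measured compound with the carbon-only ring. None of the three steps involves dipropylamino or the place two bonds along the chain, so they guide the estimate only loosely.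

A modest rise is therefore expected, with the estimated step being a 2.1-fold higher number from compound 3 to compound 4 (0.33 log units; beyond the scatter). For compound 4 the expected value in this assay is 700 10^-6 cm/s, with an estimated range of 250 10^-6 cm/s to 1500 10^-6 cm/s.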

Compound 4, apparent permeability: 913 10^-6 cm/s
The estimate for compound 4 lay 1.3-fold (0.12 log units) below the measured number, and the stated range covers the measured number.
By their numbers in this assay, from the lowest: compound 3; then compounds 4 and 1 (each within the scatter of the next). At a limit, above all of these: compound 2.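

In this assay, dipropylamino on a saturated chain carbon, two bonds along the chain from an amide-type nitrogen, brings a 2.8-fold higher number from compound 3 to compound 4 (0.44 log units; beyond the scatter), so the low number of the group with the carbon-only ring does not carry over to a group with no ring at this place. Set against (3,5-diethylpiperidin-1-yl)methyl, the same group gives a 1.4-fold lower number from compound 1 to compound 4 (0.14 log units; within the scatter), so among the compounds shown a ring is not needed for a number at this level, and compound 3 remains the only one that stands apart. The comparison with the remaining compound, an at least 1.5-fold lower number from compound 2 to compound 4 (0.18 log units; that floor lies within the scatter), rests on a limit and gives only a floor, so its true size cannot be read: the limit of > 1390 10^-6 cm/s in this assay, at which 1 of the 4 values shown sits.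

The compounds shown leave open whether dipropylamino would hold this number at the place three bonds along the chain, since the change of group and the change of place come together here. They also leave open how a smaller dimethylamino group or a morpholine ring, with its ring oxygen, would read at the same place.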